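The source may hold more compounds than are shown below. What is called first, only, known or untested is meant among the compounds shown, and "the series" means these compounds.

Compound 1 `Cn1ncc2c(=O)n(-c3ccccc3)c(CNc3cccc(F)c3)nc21` belongs to a small set of three compounds that share one core and differ in the group hanging from it. In an assay on isolated protein for inhibition of aldehyde dehydrogenase 1A1 (Homo sapiens) (a lower number here means a stronger inhibitor, a higher number a weaker inhibitor), compound 1 gives 570 nM, the highest of the three numbers, yet its gap to either neighbour stays within the scatter. Compound 2 `COc1ccccc1C(C)Sc1nc2c(cnn2C)c(=O)n1-c1ccccc1` gives 445 nM, and compound 3 `CC(Sc1nc2c(cnn2C)c(=O)n1-c1ccccc1)c1ccncc1` gives 451 nM; the step of a 1.0-fold higher number from compound 2 to compound 3 (0.01 log units; within the scatter) shows that exchanging the aromatic ring on the sulfur-linked chain left the number essentially unchanged.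

Compound 4 `Cn1ncc2c(=O)n(-c3ccccc3)c(CSc3cccc(F)c3)nc21` arises from compound 1 through ((3-fluorophenyl)sulfanyl in place of (3-fluorophenyl)amino on a saturated chain carbon bound to an aromatic carbon). Within the data shown here, no measured step changes the linking atom in this way, so the only guide is that compounds 2 and 3, which also carry a sulfur in their side chain, sit close to compound 1. A step of a 1.1-fold lower number from compound 1 to compound 4 (0.04 log units; within the scatter) is therefore expected, nothing beyond the scatter, and compound 4 is estimated at 520 nM, within 200 nM to 1400 nM.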

Compound 4, half-maximal inhibitory concentration: 720 nM
Compound 4: the middle estimate sits 1.4-fold (0.14 log units) below what was measured, and the stated range covers the measured number.
By their numbers in this assay, from the lowest: compounds 2, 3, 1 and 4 (each within the scatter of the next).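

In this assay, the exchange on a saturated chain carbon bound to an aromatic carbon gives a 1.3-fold higher number from compound 1 to compound 4 (0.10 log units; within the scatter), so compound 1 and compound 4 cannot be told apart. Among these compounds, this is the first pair in the set that differs only in the atom linking the 3-fluorophenyl ring to the chain. Sulfur takes the place of nitrogen and the group's hydrogen-bond donor count falls from 1 to 0, yet the measured step stays within the scatter for this pair. No measured evidence bears on why the two compounds read alike. Still open, from the compounds shown here alone, is how a (3-fluorophenyl)oxy group in the same place, or a longer chain carrying the 3-fluorophenyl ring, would read in this assay.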